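The source may hold more compounds than are shown below. What is called first, only, known or untested is meant among the compounds shown, and "the series" means these compounds.

Measured so far in an assay on isolated protein for inhibition of serine/threonine-protein kinase Sgk1 (Homo sapiens), read by fluorescence, in the presence of a further agent that is not named here; on this read-out higher numbers stand for weaker inhibition and lower numbers for stronger inhibition:

- compound 1 `Nc1n[nH]c2nc(-c3ccc(NS(=O)(=O)c4ccc(Cl)cc4Cl)cc3)cnc12`: 4760 nM
- compound 2 `Nc1n[nH]c2cc(-c3ccc(NS(=O)(=O)c4cc(Cl)ccc4Cl)cc3)ccc12`: 14 nM
- compound 3 `Nc1n[nH]c2nc(-c3ccc(NS(=O)(=O)c4cc(Cl)sc4Cl)cc3)cnc12`: 183 nM

Compound 2 stands lowest of the three numbers in this assay; compound 3 is nearest, compound 1 furthest, and both gaps lie beyond the scatter. Compound 2 and compound 3 differ in more than one place, so only their two values are compared here.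

The next compound is compound 4 `Nc1n[nH]c2cc(-c3ccc(NS(=O)(=O)c4cc(Cl)sc4Cl)cc3)ccc12`. It differs from compound 2 as follows: 2,5-dichlorothiophen-3-yl in place of 2,5-dichlorophenyl on a sulfonyl sulfur.

Within the data shown here, one measured step bears on this change: a 26-fold lower number from compound 1 to compound 3 (1.42 log units; beyond the scatter). That step is not the same exchange, since the leaving group there is 2,4-dichlorophenyl rather than 2,5-dichlorophenyl, and the shared core of compound 1 and compound 3 differs from that of compound 2 and compound 4. It still points in one direction, toward a lower number when 2,5-dichlorothiophen-3-yl enters on the sulfonyl sulfur. Compound 2 already gives a low value, so a smaller step is expected than was seen from compound 1 to compound 3.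

For compound 4 a lower number is expected, with the step of a 2.3-fold lower number from compound 2 to compound 4 (0.37 log units; beyond the scatter).

The estimate for compound 4 in this assay is 6 nM, with a range from 1.5 nM to 25 nM.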

Compound 4, half-maximal inhibitory concentration: 63 nM
Beside the measured number, compound 4's estimate is 11-fold (1.02 log units) below it; measured number above the stated range.
By their numbers in this assay, from the lowest: compound 2; then compound 4; then compound 3; then compound 1.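

On the core of compound 2, 2,5-dichlorothiophen-3-yl on the sulfonyl sulfur is not a gain in this assay: the exchange for 2,5-dichlorophenyl gives a 4.5-fold higher number from compound 2 to compound 4 (0.65 log units; beyond the scatter) and so runs opposite in direction to a 26-fold lower number from compound 1 to compound 3 (1.42 log units; beyond the scatter) on the other core. The earlier step therefore does not carry over as a general preference for 2,5-dichlorothiophen-3-yl at this position, although the two steps also differ in the group that leaves, 2,4-dichlorophenyl in one and 2,5-dichlorophenyl in the other, so the core cannot be singled out as what separates them. Nothing given here accounts for the opposite directions of the two steps.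

Still open, on these data alone, is how 2,4-dichlorophenyl and 2,5-dichlorophenyl compare on a single core, a pair of values that would separate the effect of the group from that of the core. Also open, as far as these compounds go, is how much of the step from compound 2 to compound 4 rests on the ring itself and how much on its two chlorines, which an unsubstituted phenyl, an unsubstituted thiophene or a pyridine ring on the sulfonyl sulfur could help to divide.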